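This account rests on a few compounds, and the source may have more. Where it says the series, first, only, none or still open, it means among the compounds named here.

Compound 1 `CNC(=O)C[C@@H]1C[C@@H](c2ccc(Cl)c(Cl)c2)[C@H](NC(=O)c2cc(-c3c(Cl)cnn3C)c(Cl)o2)CN1`: 1130 nM
Compound 2 `Cn1ncc(Cl)c1-c1cc(C(=O)N[C@@H]2CN[C@H](CCNS(C)(=O)=O)C[C@H]2c2ccc(F)c(F)c2)oc1Cl`: 1530 nM

Going by the values given here, in a functional assay on OVCAR-8 cells (Homo sapiens) for antiproliferative activity (a higher number here means a weaker inhibitor, a lower number a stronger inhibitor), compound 1 at 1130 nM and compound 2 at 1530 nM lie within the scatter of each other, so the measurements do not set compound 1 apart from its only measured neighbour.

Compound 3 `Cn1ncc(Cl)c1-c1cc(C(=O)N[C@@H]2CN[C@H](CCN3CCC(O)CC3)C[C@H]2c2ccc(Cl)c(Cl)c2)oc1Cl` has not yet been measured. Its difference from compound 1 is (4-hydroxypiperidin-1-yl)methyl in place of methylcarbamoyl on a saturated chain carbon bound to a saturated ring carbon. In words, (4-hydroxypiperidin-1-yl)methyl stands in place of methylcarbamoyl on a saturated chain carbon bound to a saturated ring carbon. Cut one bond further out, the same difference reads (methylcarbamoyl)methyl to 2-(4-hydroxypiperidin-1-yl)ethyl.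

Among the compounds with values here, no measured pair differs in one place only, so the data contain no direct precedent for this change. With no such guide, no step beyond the scatter is expected, and the estimate stays close to compound 1 at 1130 nM. The expected step is a 1.3-fold lower number from compound 1 to compound 3 (0.10 log units; within the scatter). In this assay the estimated value of compound 3 is 900 nM, with an expected range from 300 nM to 2700 nM.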

Compound 3, half-maximal inhibitory concentration: 15900 nM
Compound 3: the middle estimate sits 18-fold (1.25 log units) below what was measured, and the stated range ends below it.
By their numbers in this assay, from the lowest: compounds 1 and 2 (each within the scatter of the next); then compound 3.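

In this assay, going by these compounds alone, the exchange of methylcarbamoyl for (4-hydroxypiperidin-1-yl)methyl on a saturated chain carbon bound to a saturated ring carbon gives a 14-fold higher number from compound 1 to compound 3 (1.15 log units; beyond the scatter) and so provides the first comparison in which only one place differs. It shows that antiproliferative activity in this series responds strongly to what is carried at this position, since this single change on the core of compound 1 moves the value well beyond the scatter. The change replaces an open group with a double bond outside aromatic rings by a larger group with a six-membered non-aromatic ring, but no measurement at hand accounts for the loss.

The compounds shown leave open which part of the exchange matters, as the loss of the carbonyl, the arrival of the ring and the presence of the hydroxyl all occur together in this one step. A 2-(piperidin-1-yl)ethyl chain without the hydroxyl, a 2-morpholinoethyl chain or a 2-(dimethylamino)ethyl chain at the same place would begin to separate these parts.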